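The source may report more compounds than this note shows. Statements on the series, on what has been measured and on what is new or still open speak of the compounds shown alone.

In a functional assay on the whole organism (stomach) for inhibition, with Canis familiaris (Canis lupus familiaris) as the target, at a dose of 5 mg/kg by the intravenous route (a lower number here means a weaker effect, a higher number a stronger effect of the compound at the dose given), compound 1 `Cc1cn2cccc(OCc3ccccc3)c2n1` gives 70%. Compound 2 `Cc1nc2c(OCc3ccccc3)cccn2c1C(N)=O` gives 2% in this assay, and compound 3 `Cc1nc2c(OCc3ccccc3)cccn2c1C#N` gives 4%. Compound 3 therefore stands second highest of the three numbers, close to compound 2 and far beneath compound 1. Compound 4 `Cc1nc2c(OCc3ccccc3)cccn2c1CCC#N` is not yet measured; it differs from compound 3 in one place: 2-cyanoethyl in place of cyano on an aromatic carbon. For the measured compounds named here, two measured steps bear on this change. The first, a number 66 percentage points lower from compound 1 to compound 3 (beyond the scatter), shows that a cyano in place of hydrogen on that aromatic carbon removes most of the inhibition. The second, a number 2 percentage points higher from compound 2 to compound 3 (within the scatter), shows that exchanging cyano for carbamoyl on that aromatic carbon made no difference. Going by the values given here, no measured step lengthens a group on that carbon, so the effect of the 2-cyanoethyl is uncertain; still, both compounds carrying a group there, compound 2 and compound 3, sit low. Compound 4 is therefore expected to stay low, with an estimated step of a number 6 percentage points higher from compound 3 to compound 4 (within the scatter) that may lie within the scatter. The estimate for compound 4 is 10%, with a range from 0% to 40%.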

Compound 4, a percentage reported as inhibition, in the whole organism at one dose (the size of the read-out at that dose, not a potency): 20%
Estimate against measurement, compound 4: 10 percentage points below; the range from low to high includes it.
By their numbers in this assay, from the lowest: compounds 2 and 3 (each within the scatter of the next); then compound 4; then compound 1.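

In this assay replacing cyano with 2-cyanoethyl gives a number 16 percentage points higher from compound 3 to compound 4 (beyond the scatter) and replacing carbamoyl with it gives a number 18 percentage points higher from compound 2 to compound 4 (beyond the scatter) so the choice of group on this aromatic carbon can shift the result, something compound 2 and compound 3, within the scatter of each other, had not shown. Even so, the step of a number 50 percentage points lower from compound 1 to compound 4 (beyond the scatter) shows that 2-cyanoethyl brings back only part of the inhibition seen with hydrogen at this position. Nothing shown here explains why 2-cyanoethyl differs from cyano.

The compounds shown leave open whether the change in result follows the added chain or needs the nitrile at its end, a question that a plain ethyl group or a longer nitrile chain could address. Also open, as far as these compounds go, is how an amine or a carboxylic acid at this position would compare.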